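The compounds below may be only part of what the source reports. "The series", "measured", "known", "first", "only" and "open" are said of these compounds alone.

Compound 1 `CCC(C)C1NC(=O)N(C2CCCC2)C1=O` and compound 2 `CC(C)C1NC(=O)N(C2CCCC2)C1=O` share one core; compound 3 `CC(C)C(NC(=O)n1nnc2ccccc21)C(=O)NC1CCCC1` and the unmeasured compound 4 `CCC(C)C(NC(=O)n1nnc2ccccc21)C(=O)NC1CCCC1` share another, and the difference between the two cores is not broken down here. In a functional assay on HEL cells (Homo sapiens) for cytotoxicity (on this read-out lower numbers stand for higher toxicity in this test and higher numbers for lower toxicity in this test), compound 1 gives only a limit of the assay, > 50 ug/mL. In this assay compound 2 likewise reaches only a limit, > 50 ug/mL. In this assay, within the data shown here, compound 3 gives 200 ug/mL, the sole number among the three. The change from compound 2 to compound 1, (methyl in place of hydrogen on a saturated chain carbon, two bonds along the chain from a saturated ring carbon), yields a step that the two limits leave unreadable from compound 2 to compound 1. Compound 4 carries the same kind of change, (methyl in place of hydrogen on a saturated chain carbon, three bonds along the chain from an amide-type nitrogen and a carbonyl carbon), though its place lies three bonds along the chain from an amide-type nitrogen and a carbonyl carbon rather than two bonds along the chain from a saturated ring carbon. The expected step is a 1.1-fold lower number from compound 3 to compound 4 (0.05 log units; within the scatter), resting on (the limit of > 50 ug/mL in this assay, at which 2 of the 3 values shown sit), which leaves the measured step unreadable, so a small change is assumed. Compound 4 is thus estimated at 180 ug/mL, between 80 ug/mL and 400 ug/mL.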

Compound 4, half-maximal cytotoxic concentration: 87.3 ug/mL
Compound 4: middle estimate off by 2.1-fold (0.31 log units), on the high side; the range from low to high includes it.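

In this assay the methyl in place of hydrogen gives a 2.3-fold lower number from compound 3 to compound 4 (0.36 log units; beyond the scatter), so on this core the change from isopropyl to sec-butyl moves the read-out towards higher toxicity in this test. The same change on the core of compound 1 cannot be read, because compound 1 and compound 2 both stand at a limit of the assay: the limit of > 50 ug/mL in this assay, at which 2 of the 4 values shown sit.

Whether the step carries from one core to the other is therefore not shown, since the single readable pair neither confirms nor contradicts it. The compounds shown leave open how a longer chain than sec-butyl, or an amine or a carboxylic acid on that chain, would read in this assay. They also leave open whether the step would recur on a core where both partners give numbers.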